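The source may hold more compounds than are shown below. What is called first, only, known or untested is meant among the compounds shown, and "the series" means these compounds.

Measured in an assay on isolated protein for inhibition of aldehyde dehydrogenase 1A1 (Homo sapiens), read by spectrophotometry, tested at 10 uM; a lower number here means less inhibition, a higher number more inhibition at the concentration tested (going by the name of the read-out):
compound 1 `Cc1cccc(Cn2c(CN3CCN(C(=O)C4CCCC4)CC3)nc3ccccc32)c1` gives 67.5%
compound 2 `Cc1cccc(Cn2c(CN3CCN(C(=O)c4cccnc4)CC3)nc3ccccc32)c1` gives 24.5%
compound 3 `Cc1cccc(Cn2c(CN3CCN(C(=O)C(C)C)CC3)nc3ccccc32)c1` gives 87.2%

Compound 3 stands highest of the three in this assay. The nearest number is that of compound 1, reached by a number 19.7 percentage points higher from compound 1 to compound 3 (beyond the scatter); the furthest is that of compound 2, reached by a number 62.7 percentage points higher from compound 2 to compound 3 (beyond the scatter). The remaining step, a number 43 percentage points lower from compound 1 to compound 2 (beyond the scatter), concerns pyridin-3-yl and does not touch the present question.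

Compound 4 `Cc1cccc(Cn2c(CN3CCN(C(=O)C4CCC4)CC3)nc3ccccc32)c1` differs from compound 3 by cyclobutyl in place of isopropyl on a carbonyl carbon. Cyclobutyl is, like cyclopentyl in compound 1, a non-aromatic ring of carbon only, so the step that bears most is a number 19.7 percentage points higher from compound 1 to compound 3 (beyond the scatter), a modest one; the large step of a number 62.7 percentage points higher from compound 2 to compound 3 (beyond the scatter) involves an aromatic group and is less informative here. A modest lowering from compound 3, or no change beyond the scatter, is therefore expected, as a number 9.2 percentage points lower from compound 3 to compound 4 (within the scatter). Compound 4 is estimated at 78%, within 62% to 92%, in this assay.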

Compound 4, a percentage reported as inhibition, at one concentration (the size of the read-out at that concentration, not a potency): 69.1%
Compound 4: middle estimate off by 8.9 percentage points, on the high side, within the range that was stated.
By their numbers in this assay, from the lowest: compound 2; then compounds 1 and 4 (each within the scatter of the next); then compound 3.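

In this assay, tying the carbons of the isopropyl group into a cyclobutyl ring on the carbonyl carbon costs inhibition, with a number 18.1 percentage points lower from compound 3 to compound 4 (beyond the scatter), so compound 3 now stands clear of both non-aromatic carbon rings tested at this position. Ring size among these two rings does not separate the compounds, since cyclobutyl and cyclopentyl differ by only a number 1.6 percentage points higher from compound 1 to compound 4 (within the scatter), while the aromatic pyridin-3-yl remains clearly behind, with a number 44.6 percentage points higher from compound 2 to compound 4 (beyond the scatter). Nothing available explains these differences.

Going by these compounds, it remains open whether cyclopropyl or tert-butyl on the carbonyl carbon would match or pass compound 3. Also open, on these data alone, is how a non-aromatic ring containing nitrogen, such as piperidin-4-yl, would compare with cyclobutyl and pyridin-3-yl.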